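Two Ring Stereocentres Inverted in Compound 2

A few compounds are considered here, and "the series" means these few. Any claim that something is new, unique, unknown or untested is made for them only; others in the source may bear on it.

Compound 1 (`O=C(NCc1cc(Cl)ccc1-n1cnnn1)[C@@H]1CC=NN1C(=O)[C@H](O)c1ccccc1`): measured value (< 15 mL.min-1.g-1)
Compound 2 (`O=C(NCc1cc(Cl)ccc1-n1cnnn1)[C@@H]1C[C@H]2C[C@H]2N1C(=O)[C@H](O)c1ccccc1`): measured value (< 15 mL.min-1.g-1)

Both compounds were tested in an ADME assay on liver for metabolic stability, with Liver microsome (Rattus norvegicus) as the target, read by LC-MS, using microsomes; a higher number here means faster removal of the compound, a lower number slower removal. Compound 2 gives only a limit of the assay (< 15 mL.min-1.g-1), not a number. The same holds for the whole set so far (the limit of < 15 mL.min-1.g-1 in this assay, at which 2 of the 2 values shown sit).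

Compound 3 (`O=C(NCc1cc(Cl)ccc1-n1cnnn1)[C@@H]1C[C@@H]2C[C@@H]2N1C(=O)[C@H](O)c1ccccc1`) is the next to be tested, and it is a close relative of compound 2 (the two compounds have the same atoms and bonds and differ only in configuration as drawn: 2 of 4 stereo elements differ; a stereocentre at a saturated ring carbon is drawn R in compound 2 and S in compound 3; a stereocentre at a saturated ring carbon is drawn R in compound 2 and S in compound 3). Two stereocentres at saturated ring carbons, each drawn R in compound 2, are drawn S in compound 3.

Among the measured compounds shown here, no measured pair shows what such a change does. With compound 2 at its limit (< 15 mL.min-1.g-1), no shift beyond the usual scatter is expected in this assay. The estimated step is (a step that the limit leaves unreadable from compound 2 to compound 3). The expected value for compound 3 is (12 mL.min-1.g-1), with an estimated range from (6 mL.min-1.g-1) to (24 mL.min-1.g-1).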

Compound 3, intrinsic clearance in microsomes in the Liver microsome assay: < 15 mL.min-1.g-1
Compound 3: only a limit was reported; the forecaster's own chance of this, stated with the estimate: 65%; the middle value does not contradict the limit.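

In the Liver microsome assay compound 2 gives < 15 mL.min-1.g-1, which is a limit and not a number. In the Liver microsome assay compound 3 gives < 15 mL.min-1.g-1, which is also a limit and not a number. In the Liver microsome assay, no step can be read from compound 2 to compound 3, since neither gives a number: the limit of < 15 mL.min-1.g-1 in the Liver microsome assay, at which 3 of the 3 values shown sit. The compounds shown leave open how fast each one is actually removed, and whether the two differing ring stereocentres affect that removal at all. In a physicochemical assay for solubility, measured as kinetic solubility, at pH 6.8 (on this read-out higher numbers stand for higher solubility and lower numbers for lower solubility), compound 2 gives 100000 nM and compound 3 gives 97000 nM. In the physicochemical assay the data show a 1.0-fold lower number from compound 2 to compound 3 (0.01 log units; within the scatter).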